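Replacing thiophen-2-yl in compound 1: working notes

This account rests on a few compounds, and the source may have more. Where it says the series, first, only, none or still open, it means among the compounds named here.

Of the compounds shown here, two have been measured so far. In a functional assay on MDA-MB-435 cells (Homo sapiens) for cytotoxicity (a higher number here means a weaker inhibitor of growth, a lower number a stronger inhibitor of growth), compound 1 (`OCCCCC#Cc1ccccc1C#Cc1cccs1`) gives 16600 nM. In the same read-out, compound 2 (`OCCCCC#Cc1ccccc1C#Cc1cccc(C(F)(F)F)c1`) gives 16900 nM. These two values lie within the usual scatter of each other, so compound 1 stands level with compound 2.

The next compound to be measured is compound 3 (`OCCCCC#Cc1ccccc1C#Cc1ccc(O)cc1`). It has 4-hydroxyphenyl in place of thiophen-2-yl on a triple-bonded carbon.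

Within the data shown here, no measured pair gives a direct step for this change, and no measured compound carries the 4-hydroxyphenyl group. Among the measured compounds shown here, the only guide is that compound 1 at 16600 nM and compound 2 at 16900 nM show no separation. No step beyond the scatter is therefore expected in this assay, and no direction is favoured with any confidence. The estimated step is a 1.1-fold lower number from compound 1 to compound 3 (0.04 log units; within the scatter), and the range around it is kept wide. For compound 3, the estimated value is 15000 nM, with an expected range of 6000 nM to 40000 nM.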

Compound 3, concentration for 50% growth inhibition: 16100 nM
For compound 3 the middle estimate is 1.1-fold (0.03 log units) below the measured one; measured number inside the range.
By their numbers in this assay, from the lowest: compounds 3, 1 and 2 (each within the scatter of the next).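

In this assay the replacement of thiophen-2-yl by 4-hydroxyphenyl on a triple-bonded carbon can now be read directly, as a 1.0-fold lower number from compound 1 to compound 3 (0.01 log units; within the scatter), and the step stays within the scatter. The change is not a small one on paper: a five-membered aromatic ring with 1 hetero atom gives way to a six-membered aromatic ring of carbon only, and 1 hydrogen-bond donor enters where there was none, yet the number does not separate from that of compound 1. Nothing available on these compounds bears on why the read-out stays flat across this change.

On these data alone, all three groups seen at this place are aromatic rings, so it remains open whether a group of another kind, such as a carboxylic acid, an aminomethyl group or a saturated cyclohexyl ring, would move the number beyond the scatter. As far as these compounds go, it also remains open whether the number responds to changes at this place at all, or whether changes elsewhere on the core of compound 1, such as a longer chain in place of the one carrying the hydroxyl, matter more.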